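The compounds below may be only part of what the source reports. "The series", "measured", "known", "first", "only" and "open" are said of these compounds alone.

Compound 1 `COc1cccc2c1c(C(=O)/C=C(\O)C(=O)O)cn2Cc1c(F)cccc1F` is measured in an ADME assay on MT4 cells (Homo sapiens) for cytotoxicity, read by MTT assay (on this read-out lower numbers stand for higher toxicity in this test and higher numbers for lower toxicity in this test), where compound 1 gives 44300 nM. Compound 2 `CCOC(=O)/C(O)=C/C(=O)c1cn(Cc2ccc(F)c(F)c2F)c2cccc(OC)c12` gives 42700 nM and compound 3 `CCOC(=O)/C(O)=C/C(=O)c1cn(Cc2c(F)ccc(F)c2F)c2cccc(OC)c12` gives 40500 nM; compound 1 sits within the scatter of both, so no order among the three can be read from these numbers. Compound 4 `COc1cccc2c1c(C(=O)/C=C(\O)C(=O)O)cn2Cc1ccc(F)cc1` differs from compound 1 by 4-fluorophenyl in place of 2,6-difluorophenyl on a saturated chain carbon bound to an aromatic nitrogen. For the measured compounds named here, the one measured step that touches the same place is a 1.1-fold lower number from compound 2 to compound 3 (0.02 log units; within the scatter), a change of the fluorophenyl group on the saturated chain carbon bound to the aromatic nitrogen that left the number within the scatter. On that basis no step beyond the scatter is expected from compound 1 to compound 4, the expected step being a 1.0-fold lower number from compound 1 to compound 4 (0.00 log units; within the scatter). Compound 4 is therefore estimated at 44000 nM, with a range of 20000 nM to 95000 nM.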

Compound 4, half-maximal cytotoxic concentration: 41100 nM
Compound 4: the middle estimate sits 1.1-fold (0.03 log units) above what was measured; the range from low to high includes it.
By their numbers in this assay, from the lowest: compounds 3, 4, 2 and 1 (each within the scatter of the next).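

In this assay, going from 2,6-difluorophenyl to 4-fluorophenyl gives a 1.1-fold lower number from compound 1 to compound 4 (0.03 log units; within the scatter), so at this position a change in the number of fluorines, and not only in their arrangement, leaves the number within the scatter. This step also extends the reading from the ethyl esters to the carboxylic acids. No evidence on the cause of this result is available.

Still open, on these data alone, is whether an unsubstituted benzyl group, an amine or a longer chain at this position would give a step beyond the scatter. Also open, as far as these compounds go, is how the ethyl ester compares with the carboxylic acid on one and the same benzyl group.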